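Cyano to fluoro on the aryl group of compound 2

The source may hold more compounds than are shown below. What is called first, only, known or untested is meant among the compounds shown, and "the series" means these compounds.

In a functional assay on NCI-H460 cells (Homo sapiens) for inhibition, with a stated time of 72 h (on this read-out higher numbers stand for weaker inhibition and lower numbers for stronger inhibition), compound 1 `COc1ccc(S(=O)(=O)N2CCc3cccc(-c4ccc([N+](=O)[O-])cc4)c32)cc1` gives 53.1 nM and compound 2 `COc1ccc(S(=O)(=O)n2ccc3cccc(-c4ccc(C#N)cc4)c32)cc1` gives 172 nM on the same read-out. Compound 2 therefore holds the higher number of the two, which means weaker inhibition, and the gap lies beyond the scatter. Compound 3 `COc1ccc(S(=O)(=O)n2ccc3cccc(-c4ccc(F)cc4)c32)cc1` carries fluoro in place of cyano on an aromatic carbon, para to a large group, with fluoro in place of cyano on an aromatic carbon as the whole difference from compound 2. Among the measured compounds shown here, no measured pair shows this change. The expected step of a 1.5-fold higher number from compound 2 to compound 3 (0.16 log units; within the scatter) is small, toward weaker inhibition and probably within the scatter. For compound 3 the expected value is 250 nM with an estimated range of 80 nM to 750 nM as the likely span.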

Compound 3, half-maximal inhibitory concentration: 212 nM
Beside the measured number, compound 3's estimate is 1.2-fold (0.07 log units) above it; the range from low to high includes it.
By their numbers in this assay, from the lowest: compound 1; then compounds 2 and 3 (each within the scatter of the next).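

In this assay, fluoro in place of cyano on this aromatic carbon gives a 1.2-fold higher number from compound 2 to compound 3 (0.09 log units; within the scatter) and so leaves the read-out effectively unmoved. This first measured pair at this position shows that, between these two compounds, the nitrile can be exchanged for a single fluorine with no change that can be told from the scatter. No available evidence bears on why this exchange is tolerated. The compounds shown leave open whether an amine or a carboxylic acid at this position would give a comparable number, and whether the same exchange would read alike on the core of compound 1.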